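A few compounds are considered here, and "the series" means these few. Any claim that something is new, unique, unknown or untested is made for them only; others in the source may bear on it.

Measured compounds:
compound 1, `Cc1cc(NC(=O)Cn2nnc(-c3cccnc3)n2)n(C2CCCCC2)n1`, 1930 nM;
compound 2, `Cc1cc(NC(=O)Cn2nnc(-c3cccc(Cl)c3)n2)n(C2CCCCC2)n1`, 300 nM;
compound 3, `COc1ccc(-c2nnn(CC(=O)Nc3cc(C)nn3C3CCCCC3)n2)cc1`, 175 nM.

These were read in an assay on HEK293 cells for activation of Kir3.1/Kir3.2 (Homo sapiens), read by thallium flux; a higher number here means that more compound is needed for the effect, a lower number that less compound is needed. Compound 3 gives the lowest number of the three; its nearest neighbour is compound 2, and the step of a 1.7-fold lower number from compound 2 to compound 3 (0.23 log units; within the scatter) lies within the scatter, so the two cannot be ordered. Against compound 1 the step of an 11-fold lower number from compound 1 to compound 3 (1.04 log units; beyond the scatter) is large, and a 6.4-fold lower number from compound 1 to compound 2 (0.81 log units; beyond the scatter) is modest.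

Compound 4, `Cc1cc(NC(=O)Cn2nnc(C3CC3)n2)n(C2CCCCC2)n1`, differs from compound 3 by cyclopropyl in place of 4-methoxyphenyl on an aromatic carbon. The measured steps all exchange one six-membered aromatic ring for another; none removes the aromatic ring. Among the measured compounds shown here, the only guidance is that the group on this carbon matters, as compound 1 shows. A loss of potency is expected for compound 4, an 8.6-fold higher number from compound 3 to compound 4 (0.93 log units; beyond the scatter), with compound 4 estimated at 1500 nM in this assay, between 400 nM and 6000 nM.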

Compound 4, half-maximal effective concentration: > 3000 nM
Compound 4: a limit, no number (the forecaster's own chance of this, stated with the estimate: 15%); at least 2.0-fold (0.30 log units) between middle value and limit.
By their numbers in this assay, from the lowest: compounds 3 and 2 (each within the scatter of the next); then compound 1. At a limit, above all of these: compound 4.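

Compound 4 gives a limit, not a number: the limit of > 3000 nM in this assay, at which 1 of the 4 values shown sits. The earlier compounds shown here all kept a six-membered aromatic ring on this carbon. With cyclopropyl there, the step of an at least 17-fold higher number from compound 3 to compound 4 (1.23 log units; beyond the scatter) is large and the step of an at least 10-fold higher number from compound 2 to compound 4 (1.00 log units; beyond the scatter) is at least modest, so this smaller non-aromatic ring does not match the 4-methoxyphenyl or 3-chlorophenyl groups. The remaining step is an at least 1.5-fold higher number from compound 1 to compound 4 (0.19 log units; that floor lies within the scatter); its floor lies within the scatter, so cyclopropyl and pyridin-3-yl cannot be ordered. On these data alone, it remains open whether the aromatic ring itself matters or only the larger group, which a longer alkyl chain or a piperidine ring on this carbon could separate.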